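Ester Shortening in a Rat Cell Cytotoxicity Series

A few compounds are considered here, and "the series" means these few. Any claim that something is new, unique, unknown or untested is made for them only; others in the source may bear on it.

Compound 1 `CC(C)OC(=O)c1ccc(C2=CN3CCC2CC3)cc1` was tested in an ADME assay on L6 cells (Rattus norvegicus) for cytotoxicity, read by resazurin assay, with a stated time of 72 h (a lower number here means a stronger inhibitor, a higher number a weaker inhibitor), where compound 1 gives 152000 nM. Among the three numbers shown, compound 1 holds the second highest. Compound 3 `C(=C1/CN2CCC1CC2)\c1ccc(C2OCCO2)cc1` gives 239000 nM, a value within the scatter of compound 1. Compound 2 `C1=C(c2ccc(OCc3ccccc3)cc2)C2CCN1CC2` gives 47200 nM, a number beyond the scatter and lower than that of compound 1. Compound 4 `CCOC(=O)c1ccc(C2=CN3CCC2CC3)cc1` has not yet been measured in this assay. It differs from compound 1 in one place: hydrogen in place of methyl on a saturated chain carbon bound to an oxygen next to a carbonyl group and a saturated chain carbon. Among the compounds with values here, no comparable step between measured compounds is available. The step of a 1.0-fold lower number from compound 1 to compound 4 (0.01 log units; within the scatter) is expected to fall within the scatter, in no particular direction. Compound 4 is estimated at 150000 nM, within a range from 60000 nM to 350000 nM.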

Compound 4, half-maximal inhibitory concentration: 265000 nM
Compound 4: middle estimate off by 1.8-fold (0.25 log units), on the low side; measured number inside the range.
By their numbers in this assay, from the lowest: compound 2; then compounds 1, 3 and 4 (each within the scatter of the next).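

In this assay, going from isopropoxycarbonyl to ethoxycarbonyl gives a 1.7-fold higher number from compound 1 to compound 4 (0.24 log units; within the scatter) on the shared core. This first direct one-place comparison shows that exchanging this methyl for hydrogen does not separate the two compounds in this read-out. No supporting measurement is available to explain the result.

On these data alone, it remains open whether a longer chain such as butoxycarbonyl, or a carboxylic acid in place of the ester, would move the number beyond the scatter. A single step also cannot show how this position responds to larger changes.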